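Trading a hydroxy for a methyl

The compounds below may be only part of what the source reports. "The series", "measured", "known", "first", "only" and "open" are said of these compounds alone.

In a functional assay on A498 cells (Homo sapiens) for cytotoxicity (a lower number here means a stronger inhibitor of growth, a higher number a weaker inhibitor of growth), compound 2 `CSc1ccc(C2=C(c3ccc(O)cc3)C(=O)N3CCCC3C2)cc1` gives > 100000 nM, which is a limit and not a number. Compound 1 `CSc1ccc(C2=C(c3ccc(C)c(C)c3)C(=O)N3CCCC3C2)cc1` gives 300 nM in this assay. Going by the values given here, the only measured step, an at least 330-fold higher number from compound 1 to compound 2 (2.52 log units; beyond the scatter), put 4-hydroxyphenyl in place of 3,4-dimethylphenyl and was large. Compound 3 `CSc1ccc(C2=C(c3ccc(C)cc3)C(=O)N3CCCC3C2)cc1` carries methyl in place of hydroxy on an aromatic carbon, a change from 4-hydroxyphenyl to 4-methylphenyl, which restores one of the two methyl groups of compound 1. A large move toward a lower number is therefore expected in this assay, undoing most of that step. The expected step is an at least 100-fold lower number from compound 2 to compound 3 (2.00 log units; beyond the scatter). Compound 3 is estimated at 1000 nM, with a range of 200 nM to 8000 nM.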

Compound 3, concentration for 50% growth inhibition: 4000 nM
Beside the measured number, compound 3's estimate is 4.0-fold (0.60 log units) below it; measured number inside the range.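

In this assay, putting methyl in place of hydroxy brings back much of the growth inhibition (an at least 25-fold lower number from compound 2 to compound 3 (1.39 log units; beyond the scatter)), so the group on this aromatic carbon matters on its own, without the second methyl of compound 1. That second methyl still counts (a 13-fold higher number from compound 1 to compound 3 (1.12 log units; beyond the scatter)). Compound 2 stands at a limit and not at a number, so the step from it gives only a minimum size: the limit of > 100000 nM in this assay, at which 1 of the 3 values shown sits.

Still open, going by these compounds, is whether an amine, a methoxy group or a longer chain such as ethyl on this carbon would behave like methyl or like hydroxy.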